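Adding Trifluoromethyl to the Biaryl Analogue

A few compounds are considered here, and "the series" means these few. Any claim that something is new, unique, unknown or untested is made for them only; others in the source may bear on it.

Compound 1 `Cc1ccccc1Cc1ccc(N2CCC[C@H]2CC(=O)O)cc1`: in an assay on HEK293 cells for binding affinity to Free fatty acid receptor 1 (Homo sapiens), read by scintillation counting and radioligand binding, with a stated time of 1 h (a lower number here means a stronger inhibitor, a higher number a weaker inhibitor), compound 1 gives 1300 nM.
Compound 2 `Cc1ccccc1Cc1ccc(N2C[C@@H](C(F)(F)F)C[C@H]2CC(=O)O)cc1`: compound 2 gives 73 nM.
Compound 3 `COc1ccc(F)c(-c2ccc(Cc3ccc(N4CCC[C@H]4CC(=O)O)cc3)c(C)c2)c1`: compound 3 gives 310 nM.

Among the three measured numbers, compound 3 has the second highest. Its number is lower than that of compound 1, as shown by a 4.2-fold lower number from compound 1 to compound 3 (0.62 log units; beyond the scatter), while compound 2 sits lower still, so compound 3 stands in the middle.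

Compound 4 `COc1ccc(F)c(-c2ccc(Cc3ccc(N4C[C@@H](C(F)(F)F)C[C@H]4CC(=O)O)cc3)c(C)c2)c1` differs from compound 3 in one place: trifluoromethyl in place of hydrogen on a saturated ring carbon. Exactly this change has been measured once already, on the core of compound 1: an 18-fold lower number from compound 1 to compound 2 (1.25 log units; beyond the scatter). That single step bears directly on the present one. It is the same group entering at the same position of the same ring, only with the larger aromatic group of compound 3 in place. A large drop in this assay is therefore expected for compound 4, with the caveat that one example cannot fix the size precisely. Compound 4 is estimated at 25 nM, within a range from 8 nM to 80 nM, which corresponds to an expected step of a 12-fold lower number from compound 3 to compound 4 (1.09 log units; beyond the scatter).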

Compound 4, inhibition constant: 45 nM
Estimate against measurement, compound 4: 1.8-fold (0.26 log units) below; measured number inside the range.
By their numbers in this assay, from the lowest: compounds 4 and 2 (each within the scatter of the next); then compound 3; then compound 1.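

The drop from adding trifluoromethyl at this saturated ring carbon is not confined to the core of compound 1, as it appears again with the larger aromatic group in place, a 6.9-fold lower number from compound 3 to compound 4 (0.84 log units; beyond the scatter). The two steps agree as closely as their scatter allows: the same change on two cores in this assay, an 18-fold lower number (1.25 log units; beyond the scatter) from compound 1 to compound 2 and a 6.9-fold lower number (0.84 log units; beyond the scatter) from compound 3 to compound 4, 2.6-fold (0.41 log units) apart, within the scatter of two such steps. Read the other way, once trifluoromethyl is present, the 2-fluoro-5-methoxyphenyl group gives a step that cannot be told from scatter, a 1.6-fold lower number from compound 2 to compound 4 (0.21 log units; within the scatter), yet this does not prove that its contribution really shrinks: the same change on two cores in this assay, a 4.2-fold lower number (0.62 log units; beyond the scatter) from compound 1 to compound 3 and a 1.6-fold lower number (0.21 log units; within the scatter) from compound 2 to compound 4, 2.6-fold (0.41 log units) apart, within the scatter of two such steps.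

As far as these compounds go, whether a methyl group, a single fluorine or a hydroxyl group on this ring carbon would also lower the number remains open. With only two cores shown, the size of the trifluoromethyl step on a third core also remains open.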